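A few compounds are considered here, and "the series" means these few. Any claim that something is new, unique, unknown or untested is made for them only; others in the source may bear on it.

Working notes on the series. Values in a functional assay on MDA-MB-231 cells (Homo sapiens) for antiproliferative activity, read by sulforhodamine B assay, with a stated time of 72 h (on this read-out lower numbers stand for stronger inhibition and higher numbers for weaker inhibition), follow.

- Compound 1 `O=C1C=CCC/C1=C\c1cnc2ccccc2c1` gives 640 nM
- Compound 2 `CC(=O)n1cc(/C=C2\CCC=CC2=O)c2ccccc21` gives 930 nM
- Compound 3 `COc1cc(/C=C2\CNC=CC2=O)cc(OC)c1OC` gives > 25000 nM as a limit

Compound 3 sits at > 25000 nM as a limit of the assay and not a number. Its true position is therefore unknown, and any step from it can only be stated loosely.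

The next compound is compound 4 `COc1cc(/C=C2\CN(S(=O)(=O)c3ccc(C)cc3)C=CC2=O)cc(OC)c1OC`, not yet measured. The change is (4-methylphenyl)sulfonyl in place of hydrogen on an amine nitrogen in a ring with (4-methylphenyl)sulfonyl in place of hydrogen on an amine nitrogen in a ring.

Going by the values given here, no measured pair isolates this change, so the expectation rests on thin ground. Of the three measured compounds, only compound 3 has a hydrogen on an amine nitrogen in a ring. The two without one give numbers, compound 1 with 640 nM and compound 2 with 930 nM, although their cores differ from that of compound 3. On that basis, stronger inhibition is expected, well beyond the scatter, with the estimated move being an at least 12-fold lower number from compound 3 to compound 4 (1.09 log units; beyond the scatter) in this assay as a working figure.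

Compound 4 is estimated at 2000 nM with an expected range from 300 nM to 12000 nM for now.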

Compound 4, half-maximal inhibitory concentration: 22200 nM
For compound 4 the middle estimate is 11-fold (1.05 log units) below the measured one, and the stated range ends below it.
By their numbers in this assay, from the lowest: compounds 1 and 2 (each within the scatter of the next); then compound 4. At a limit, above all of these: compound 3.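

In this assay, (4-methylphenyl)sulfonyl in place of hydrogen on an amine nitrogen in a ring gives an at least 1.1-fold lower number from compound 3 to compound 4 (0.05 log units; that floor lies within the scatter). Going by these compounds alone, with this group in place, compound 4 gives 22200 nM, so this nitrogen position now has a measured number on the read-out, which the earlier compounds did not provide for this core. The true size of the step remains unfixed, and the result cannot show whether the change brings any real gain, because compound 3 stands at a limit of the assay and not at a number: the limit of > 25000 nM in this assay, at which 1 of the 4 values shown sits.

On these data alone, it remains open whether any effect of the change belongs to the sulfonyl link or to the 4-methylphenyl ring that it carries. As far as these compounds go, it is also open how this nitrogen position responds to simpler groups such as a methyl or a benzyl group, which would show whether a number on this core depends on the sulfonyl link at all.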